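This account rests on a few compounds, and the source may have more. Where it says the series, first, only, none or still open, it means among the compounds named here.

Series notes. In a functional assay on HeLa cells (Homo sapiens) for inhibition (on this read-out higher numbers stand for weaker inhibition and lower numbers for stronger inhibition), compound 1 `Oc1cccc(-c2cc(-c3ccc(C(F)(F)F)cc3)cc(-c3ccccc3O)n2)c1` gives > 50000 nM, which is a limit of the assay and not a number. Compound 2 `Oc1cccc(-c2cc(-c3ccc(C(F)(F)F)cc3)cc(-c3cccc(O)c3)n2)c1` gives > 50000 nM in this assay, again a limit. The step that the two limits leave unreadable from compound 1 to compound 2 therefore cannot be sized. For the measured compounds named here, compound 3 `Oc1ccc(-c2cc(-c3ccccc3C(F)(F)F)cc(-c3cccc(O)c3)n2)cc1` gives 17400 nM in this assay and is the only compound with a measured number; the rest of the picture is the limit of > 50000 nM in this assay, at which 2 of the 3 values shown sit. Compound 4 `Oc1ccc(-c2cc(-c3ccc(C(F)(F)F)cc3)cc(-c3cccc(O)c3)n2)cc1` is not yet measured. The change from compound 3 is 4-(trifluoromethyl)phenyl in place of 2-(trifluoromethyl)phenyl on an aromatic carbon; both hydroxyphenyl groups remain as in compound 3. Going by the values given here, none of the measured steps touches the trifluoromethyl position, so no step bears directly on this change, and the one step between measured neighbours concerns the hydroxyphenyl position and is itself unreadable. Compound 2, which carries the same 4-(trifluoromethyl)phenyl group that enters here, returned only a limit. For compound 4 the expectation in this assay is a weakening of about a 2.0-fold higher number from compound 3 to compound 4 (0.30 log units; within the scatter), with a real chance that only a limit is reported. The estimate for compound 4 in this assay is 35000 nM, expected to lie within 12000 nM to 100000 nM.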

Compound 4, half-maximal inhibitory concentration: 17300 nM
Compound 4: the middle estimate sits 2.0-fold (0.31 log units) above what was measured, and the stated range covers the measured number.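

In this assay, 4-(trifluoromethyl)phenyl in place of 2-(trifluoromethyl)phenyl, on the aromatic carbon opposite the ring nitrogen, gives a 1.0-fold lower number from compound 3 to compound 4 (0.00 log units; within the scatter), so the two placements of the trifluoromethyl group cannot be told apart in this pair. With the 4-(trifluoromethyl)phenyl group held fixed, the hydroxyphenyl position can now be read: 4-hydroxyphenyl in place of 3-hydroxyphenyl gives an at least 2.8-fold lower number from compound 2 to compound 4 (0.46 log units; beyond the scatter), and 4-hydroxyphenyl in place of 2-hydroxyphenyl gives an at least 2.8-fold lower number from compound 1 to compound 4 (0.46 log units; beyond the scatter). The 4-(trifluoromethyl)phenyl group therefore does not by itself hold a compound at the limit, and both of these steps start from a limit of the assay and not from a number: the limit of > 50000 nM in this assay, at which 2 of the 4 values shown sit.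

The compounds shown carry only hydroxyphenyl and trifluoromethyl-substituted phenyl groups at these positions, so it stays open how an amine or a carboxylic acid in place of the hydroxyl, or a nitrile in place of the trifluoromethyl group, would read in this assay. The step between the 2-hydroxyphenyl and 3-hydroxyphenyl compounds, compound 1 and compound 2, still cannot be read.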